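The compounds below may be only part of what the source reports. "The series", "measured", "known", "first", "only" and "open" are said of these compounds alone.

Compound 1 (`C/C(=N\NC(N)=O)c1ccc2[nH]c(-c3ccc(C(F)(F)F)cc3)nc2c1`), compound 2 (`C/C(=N\NC(N)=S)c1ccc2[nH]c(-c3ccc(C(F)(F)F)cc3)nc2c1`) and compound 3 (`COc1ccc(-c2nc3cc(/C(C)=N/NC(N)=S)ccc3[nH]2)cc1`) share one core. In an ADME assay on MT4 cells (Homo sapiens) for cytotoxicity, read by MTT assay, with a stated time of 96 h (on this read-out lower numbers stand for higher toxicity in this test and higher numbers for lower toxicity in this test), compound 1 has the entry "not determined" (no result reported), so it offers no number. Compound 2 gives 2000 nM, the lower of the two numbers available, and compound 3 gives 5000 nM. Compound 4 (`C/C(=N\NC(N)=S)c1ccc2c(c1)nc(-c1ccc(C(F)(F)F)cc1)n2C1CCCCC1`) comes from compound 2 by one change: cyclohexyl in place of hydrogen on an aromatic nitrogen. Among the measured compounds shown here, the only measured step, a 2.5-fold higher number from compound 2 to compound 3 (0.40 log units; beyond the scatter), was modest and took place on an aromatic carbon, not on the aromatic nitrogen, so it offers only a rough guide to size. No clear shift beyond the scatter is therefore expected in this assay, and the expected step is a 1.5-fold higher number from compound 2 to compound 4 (0.18 log units; within the scatter). For compound 4 the estimated value is 3000 nM, with an expected range of 800 nM to 15000 nM.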

Compound 4, half-maximal cytotoxic concentration: 30000 nM
Compound 4: the middle estimate sits 10-fold (1.00 log units) below what was measured; the measured number lies above the stated range.
By their numbers in this assay, from the lowest: compound 2; then compound 3; then compound 4.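

In this assay, among the compounds shown here, the aromatic nitrogen proves a far more responsive place than the earlier compounds could reveal: cyclohexyl in place of hydrogen gives a 15-fold higher number from compound 2 to compound 4 (1.18 log units; beyond the scatter), which stands for lower toxicity in this test. For the compounds shown here, the only earlier step, a 2.5-fold higher number from compound 2 to compound 3 (0.40 log units; beyond the scatter), came from a change on an aromatic carbon and is smaller. Nothing available explains why the number rises.

From the compounds shown here alone, whether a methyl group or a chain carrying an amine on that nitrogen would shift the number as far stays open. So does whether cyclohexyl would act alike alongside methoxy instead of trifluoromethyl.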